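Methyl on the pyridine ring in thiosemicarbazide cytotoxicity series

The compounds below may be only part of what the source reports. "The series", "measured", "known", "first", "only" and "open" are said of these compounds alone.

The measured compounds and their values:
compound 1, `N/C(=N\NC(=S)N1CCCCCC1)c1ccccn1`, 82.9%
compound 2, `Cc1ccnc(/C(N)=N/NC(=S)N2CCSCC2)c1`, 78.3%
compound 3, `N/C(=N\NC(=S)N1CCSCC1)c1ccccn1`, 80.6%

All three were tested in a functional assay on HeLa cells (Homo sapiens) for cytotoxicity, read by MTT assay, with a stated time of 72 h, tested at 30 uM; a lower number here means less inhibition of growth, a higher number more inhibition of growth at the concentration tested. Compound 1 gives the highest of the three numbers, but its nearest neighbour, compound 3, lies only a number 2.3 percentage points lower from compound 3 to compound 2 (within the scatter) away in the opposite direction of the same kind of comparison, and all three values sit within the scatter of one another, so no order among them can be read. The change from compound 3 to compound 2 is methyl in place of hydrogen on an aromatic carbon, and it gave a number 2.3 percentage points lower from compound 3 to compound 2 (within the scatter), a step within the scatter. How the core of compound 1 differs from that of compound 3 is not broken down here.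

Compound 4, `Cc1ccnc(/C(N)=N/NC(=S)N2CCCCCC2)c1`, has not yet been measured. It differs from compound 1 by methyl in place of hydrogen on an aromatic carbon, the same change, at the same place, as that from compound 3 to compound 2. Because that change gave a number 2.3 percentage points lower from compound 3 to compound 2 (within the scatter), a step of about the same small size, a number 2.4 percentage points lower from compound 1 to compound 4 (within the scatter), is expected here. Compound 4 is therefore estimated at 80.5% in this assay, between 70% and 90%.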

Compound 4, percent growth inhibition at one concentration: 69.9%
Estimate against measurement, compound 4: 10.6 percentage points above; measured number below the stated range.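

In this assay, methyl in place of hydrogen on an aromatic carbon gave a number 13 percentage points lower from compound 1 to compound 4 (beyond the scatter), so on this core the step stands clear of the scatter. Set beside the earlier step on the other core, however, it cannot be told apart from it: the same change on two cores in this assay, a number 2.3 percentage points lower (within the scatter) from compound 3 to compound 2 and a number 13 percentage points lower (beyond the scatter) from compound 1 to compound 4, 10.7 percentage points apart, within the scatter of two such steps The pair therefore does not show that the core of compound 1 responds to this methyl differently from the core of compound 3, nor does it show that the change carries from one core to another at a fixed size, and two steps cannot settle what it would do on a further core.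

The compounds shown carry only hydrogen or methyl at this place, opposite the ring nitrogen, so the effect of an ethyl group, a methoxy group or a chlorine atom there remains open. Also open, on these data alone, is how the methyl step would run with a dimethylamino group in place of the ring that separates compound 1 from compound 3.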